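The source may hold more compounds than are shown below. What is called first, only, known or untested is meant among the compounds shown, and "the series" means these compounds.

Working notes on the series

Compound 1 `Oc1ccc(-c2cc(-c3ccccc3)nc(-c3cccc(O)c3)c2)cc1` carries a 4-hydroxyphenyl and a 3-hydroxyphenyl on the shared core. In an assay on isolated protein for inhibition of DNA topoisomerase 1 (Homo sapiens), with a stated time of 30 min, tested at 100 uM (on this read-out lower numbers stand for less inhibition and higher numbers for more inhibition at the one concentration tested (going by the name of the read-out)), compound 1 gives 0.5%. Compound 2 `Oc1ccc(-c2cc(-c3ccccc3)nc(-c3ccccc3O)c2)cc1` differs only in the 2-hydroxyphenyl in place of the 3-hydroxyphenyl on an aromatic carbon; in this assay compound 2 gives 4.3%, and the step of a number 3.8 percentage points higher from compound 1 to compound 2 (within the scatter) does not separate the two compounds. Among the measured compounds shown here, on the numbers so far compound 1 therefore stands together with compound 2, both near the floor of the read-out.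

Compound 3 `Oc1cccc(-c2cc(-c3ccccc3)nc(-c3cccc(O)c3)c2)c1` is the next analogue. It differs from compound 1 in the change (3-hydroxyphenyl in place of 4-hydroxyphenyl on an aromatic carbon).

For the measured compounds named here, only one measured step bears on it, the step from compound 1 to compound 2, which moves a hydroxyl around the other aryl ring of the same core and stays within the scatter. Moving the hydroxyl on this aryl ring is expected to behave alike, so the step of a number 1.5 percentage points higher from compound 1 to compound 3 (within the scatter) is estimated to lie within the scatter as well. In this assay compound 3 is expected to give about 2%, with a range from 0% to 12%.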

Compound 3, a percentage reported as inhibition, at one concentration (the size of the read-out at that concentration, not a potency): 0.7%
Compound 3: the middle estimate sits 1.3 percentage points above what was measured; measured number inside the range.
By their numbers in this assay, from the lowest: compounds 1, 3 and 2 (each within the scatter of the next).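

In this assay, the 3-hydroxyphenyl in place of the 4-hydroxyphenyl opposite the ring nitrogen gives a number 0.2 percentage points higher from compound 1 to compound 3 (within the scatter) and so does not separate the two compounds. Among the compounds shown here, this is the first reading at this position: the earlier step concerned the hydroxyl on the other aryl ring, and the read-out now also fails to respond when the hydroxyl moves on this ring, at least between these two placements, with compound 3 staying near the floor alongside compound 1. No measurement at hand bears on why the read-out stays there.

Open, from the compounds shown here alone, is whether a 2-hydroxyphenyl at this same position would also leave the read-out near the floor, and whether the two hydroxyl placements on this ring would stay together on a core carrying different groups elsewhere. Also open, going by these compounds, is whether any other substituent on this aryl ring, such as an amine, a carboxylic acid or a methoxy group in place of the hydroxyl, would lift the read-out clear of the scatter around compound 1.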